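Swapping an aromatic ring on a highly protein-bound series

A few compounds are considered here, and "the series" means these few. Any claim that something is new, unique, unknown or untested is made for them only; others in the source may bear on it.

The compounds here share a common core with a phenyl ring that carries a small five-membered aromatic ring. Compound 1 `O=C(C1=C(O)C(=O)N(c2ccc(-c3ccon3)cc2)C1C1CCCCC1)c1ccc(CO)cc1` and compound 2 `COc1ccc(C(=O)C2=C(O)C(=O)N(c3ccc(-c4ccon4)cc3)C2c2ccccc2OCCO)cc1` have both been tested in an ADME assay on the whole organism (serum, Rattus norvegicus) for protein binding; a higher number here means a larger unbound share of the compound, a lower number a smaller unbound share. In this assay compound 1 gives 0.004, and compound 2 gives 0.003; the two numbers sit within the usual scatter of each other, and both show that only a very small share of each compound is free in serum. In this assay compound 3 `Cc1cc(-c2ccc(N3C(=O)C(O)=C(C(=O)C(C)(C)C)C3c3ccccc3OCCO)cc2)on1` gives "not determined" (no result reported), so its own position cannot be stated. Compound 4 `CC(C)(C)C(=O)C1=C(O)C(=O)N(c2ccc(-c3cccs3)cc2)C1c1ccccc1OCCO` differs from compound 3 by thiophen-2-yl in place of 3-methyl-1,2-oxazol-5-yl on an aromatic carbon. For the measured compounds named here, no measured step is available for this change. With both measured neighbours bound almost completely, the expectation is that compound 4 stays in the same very low range, with no step beyond the scatter in either direction. Compound 4 is therefore expected to give about 0.003 in this assay, most likely between 0.001 and 0.008.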

Compound 4, unbound fraction: 0.001
Beside the measured number, compound 4's estimate is 3.0-fold (0.48 log units) above it; the range from low to high includes it.
By their numbers in this assay, from the lowest: compound 4; then compounds 2 and 1 (each within the scatter of the next).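

In this assay, for the compounds shown here, compound 3 gives "not determined" (no result reported) and so no step to compound 4 can be read. The compounds shown leave open whether thiophen-2-yl in place of 3-methyl-1,2-oxazol-5-yl shifts the unbound share at all. Nothing shown here explains the value of compound 4.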